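A few compounds are considered here, and "the series" means these few. Any claim that something is new, unique, unknown or untested is made for them only; others in the source may bear on it.

Measured so far:
Compound 1 `CCOC(=O)CCCCCOc1cccc(CN(C(=O)c2ccc(-c3ccc4cc[nH]c4c3)cc2)C(C)C)c1` gives > 26000 nM (a limit)
Compound 2 `CCOC(=O)CCCCCOc1cccc(CN(C(=O)c2ccc(-c3cc(F)cc(OC)c3)cc2)C(C)C)c1` gives > 26000 nM (a limit)
Compound 3 `CCOC(=O)CCCCCOc1cccc(CN(C(=O)c2ccc(-c3cccc(S(C)(=O)=O)c3)cc2)C(C)C)c1` gives > 26000 nM (a limit)

In an ADME assay on Raji cells (Homo sapiens) for cytotoxicity, read by CellTiter-Glo and resazurin assay, with a stated time of 72 h (on this read-out higher numbers stand for an effect only at larger amounts of compound and lower numbers for an effect already at smaller amounts), compound 3 stands at > 26000 nM and this is a limit of the assay, not a number. The picture so far is the limit of > 26000 nM in this assay, at which 3 of the 3 values shown sit, and so no measured number exists yet.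

Going on to compound 4 `CCOC(=O)CCCCCOc1cccc(CN(C(=O)c2ccc(Br)cc2)C(C)C)c1` means bromo in place of 3-(methylsulfonyl)phenyl on an aromatic carbon, and the full count is bromo in place of 3-(methylsulfonyl)phenyl on an aromatic carbon for this change.

Three measured steps change the group at this same place: a step that the two limits leave unreadable from compound 1 to compound 2 and a step that the two limits leave unreadable from compound 1 to compound 3 and a step that the two limits leave unreadable from compound 2 to compound 3 are the ones that bear on it. Their sizes cannot be read, and none of them brings in bromo, so they offer no size to carry over. With three different groups at one limit, no step beyond the scatter is expected in this assay and no direction can be named. The expected outcome is a number no higher from compound 3 to compound 4 (the limit leaves the size open) and another limit is the likeliest report. For compound 4 the estimate is 26000 nM with an expected range from 10000 nM to 40000 nM.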

Compound 4, half-maximal effective concentration: > 26000 nM
Compound 4: only a limit was reported; the forecaster's own chance of this, stated with the estimate: 85%; the middle value lies on the limit itself.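

Compound 4 is again reported only as a limit in this assay, and the steps to it from compound 1, compound 2 and compound 3 cannot be read. The compounds shown leave open whether changing the group at this place alters the effect at all, with every value on one limit: the limit of > 26000 nM in this assay, at which 4 of the 4 values shown sit.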